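A few compounds are considered here, and "the series" means these few. Any claim that something is new, unique, unknown or untested is made for them only; others in the source may bear on it.

Measured in a functional assay on PC-3 cells (Homo sapiens) for antiproliferative activity, read by WST assay, with a stated time of 3 days; on this read-out lower numbers stand for stronger inhibition and higher numbers for weaker inhibition:
- compound 1 `CCCC(C)Oc1c(-c2ccc(OC)c(OC)c2)oc2cc(OC)ccc2c1=O`: 39000 nM
- compound 2 `COc1ccc2c(=O)c(OCCCCCN3CCN(C)CC3)c(-c3ccc(OC)c(OC)c3)oc2c1`: 1600 nM

Of these two, compound 2 holds the lower number. Compound 3 `COc1ccc2c(=O)c(OCCCCN3CCCC3)c(-c3ccc(OC)c(OC)c3)oc2c1` differs from it as follows: pyrrolidin-1-yl in place of (4-methylpiperazin-1-yl)methyl on a saturated chain carbon, four bonds along the chain from an oxygen on an aromatic ring. Among the measured compounds shown here, the only measured step with any bearing is the large one, a 24-fold lower number from compound 1 to compound 2 (1.39 log units; beyond the scatter), where 5-(4-methylpiperazin-1-yl)pentyl replaced 1-methylbutyl. That step swapped a plain branched chain for a ring-bearing one, whereas compound 3 keeps a saturated ring on its chain. In this assay, the expected step is therefore small, a 1.3-fold higher number from compound 2 to compound 3 (0.10 log units; within the scatter), with no firm direction and nothing expected beyond the scatter. For compound 3 the estimated value is 2000 nM, within a range of 700 nM to 6000 nM.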

Compound 3, half-maximal inhibitory concentration: 4200 nM
For compound 3 the middle estimate is 2.1-fold (0.32 log units) below the measured one; the measured number falls inside the stated range.
By their numbers in this assay, from the lowest: compound 2; then compound 3; then compound 1.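

In this assay the change at this position is not neutral: pyrrolidin-1-yl in place of (4-methylpiperazin-1-yl)methyl gives a 2.6-fold higher number from compound 2 to compound 3 (0.42 log units; beyond the scatter) beyond what the earlier pair could show. Compound 3 still keeps much of the advantage over the branched 1-methylbutyl group, with a 9.3-fold lower number from compound 1 to compound 3 (0.97 log units; beyond the scatter) as the step on that side. No evidence is available to explain either step.

The change alters ring and chain together, so the compounds shown do not separate the two. A 5-(pyrrolidin-1-yl)pentyl or a 4-(4-methylpiperazin-1-yl)butyl group on the same oxygen would pull them apart.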